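Five-membered heteroaryl replacements at the benzyl terminus

The compounds below may be only part of what the source reports. "The series", "measured", "known", "first", "only" and "open" are said of these compounds alone.

Compound 2 `Cc1cc(C)c(NC(=O)N(Cc2ccc(-c3cnn(C)c3)cc2)C2CCCCCC2)c(C)c1` holds the higher of the two numbers measured in an assay on microsomes from intestine for inhibition of acyl-CoA:cholesterol acyltransferase (Oryctolagus cuniculus); a higher number here means a weaker inhibitor, a lower number a stronger inhibitor: compound 2 gives 47 nM, while compound 1 `Cc1cc(C)c(NC(=O)N(Cc2ccc(-c3cccs3)cc2)C2CCCCCC2)c(C)c1` gives 22 nM. For the measured compounds named here, the only step available, a 2.1-fold higher number from compound 1 to compound 2 (0.33 log units; beyond the scatter), exchanged one five-membered heteroaryl for another and raised the number modestly. Compound 3 `Cc1cc(C)c(NC(=O)N(Cc2ccc(-n3ccnn3)cc2)C2CCCCCC2)c(C)c1` continues along that line: 1H-1,2,3-triazol-1-yl in place of 1-methyl-1H-pyrazol-4-yl on an aromatic carbon. Going by the values given here, no measured pair shows this particular exchange, so the step from compound 1 to compound 2 is the only guide, and it points to a modest rise at most. For compound 3 a small further increase is expected, a 1.6-fold higher number from compound 2 to compound 3 (0.20 log units; within the scatter), with a real chance that the number stays within the scatter of compound 2. The estimate for compound 3 in this assay is 75 nM, expected to fall between 25 nM and 220 nM.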

Compound 3, half-maximal inhibitory concentration: 42 nM
The estimate for compound 3 lay 1.8-fold (0.25 log units) above the measured number, within the range that was stated.
By their numbers in this assay, from the lowest: compounds 1, 3 and 2 (each within the scatter of the next, the first and the last beyond it).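

In this assay, the exchange of 1-methyl-1H-pyrazol-4-yl for 1H-1,2,3-triazol-1-yl at this position, para to a large group, is a 1.1-fold lower number from compound 2 to compound 3 (0.05 log units; within the scatter), so a ring with 3 hetero atoms in place of 2 leaves compound 3 indistinguishable from compound 2. Against the thiophen-2-yl group the step is a 1.9-fold higher number from compound 1 to compound 3 (0.28 log units; within the scatter), which also leaves compound 3 within the scatter of compound 1, and a 2.1-fold higher number from compound 1 to compound 2 (0.33 log units; beyond the scatter) remains the only step of the three beyond the scatter. Nothing available on these compounds bears on what lies behind these numbers.

All three groups shown here are five-membered aromatic rings, so the response to a six-membered ring such as pyridin-3-yl remains open. As far as these compounds go, a carboxylic acid or an amine such as morpholin-4-yl at this position is also open.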